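A few compounds are considered here, and "the series" means these few. Any claim that something is new, unique, unknown or untested is made for them only; others in the source may bear on it.

Measured compounds:
- compound 1 `Fc1ccc(-c2cn3ccnc3c(-c3ccc4ncn(C5CCCCC5)c4c3)n2)cc1`: 15.5%
- compound 2 `CCc1ccc(-c2cn3ccnc3c(-c3ccc4ncn(Cc5ccccc5)c4c3)n2)cc1`: 45.9%

Of the compounds shown here, two have been measured in a functional assay on NCI-H522 cells (Homo sapiens) for inhibition, read by sulforhodamine B assay, with a stated time of 48 h, tested at 10 uM; on this read-out higher numbers stand for more inhibition at the one concentration tested (going by the name of the read-out) and lower numbers for less inhibition. Compound 1 `Fc1ccc(-c2cn3ccnc3c(-c3ccc4ncn(C5CCCCC5)c4c3)n2)cc1` gives 15.5% in this assay, and compound 2 `CCc1ccc(-c2cn3ccnc3c(-c3ccc4ncn(Cc5ccccc5)c4c3)n2)cc1` gives 45.9%. Of the two numbers, compound 2 stands highest, and the nearest number, that of compound 1, lies lower by a distance beyond the usual scatter. The two compounds differ in more than one place, so the values alone show that compound 2 reached the higher inhibition, and nothing more.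

Compound 3 `O=Cc1ccc(-c2cn3ccnc3c(-c3ccc4ncn(Cc5ccccc5)c4c3)n2)cc1` has not yet been measured in this assay. It is built from compound 2 by a single change: formyl in place of ethyl on an aromatic carbon. Among the measured compounds shown here, no measured pair shows what such an exchange of one group for another on that ring does here, so the direction of the step can only be estimated. The step of a number 10.9 percentage points lower from compound 2 to compound 3 (beyond the scatter) is expected to be a modest downward one, about the size of the scatter, leaving the value of compound 3 in the middle of the range set by the two measured compounds. For compound 3 the expected value in this assay is 35%, within a range from 12% to 58%.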

Compound 3, a percentage reported as inhibition, at one concentration (the size of the read-out at that concentration, not a potency): 25.3%
Estimate against measurement, compound 3: 9.7 percentage points above, and the stated range covers the measured number.
By their numbers in this assay, from the lowest: compounds 1 and 3 (each within the scatter of the next); then compound 2.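

In this assay, among the compounds shown here, compound 2 and compound 3 form the first pair that differs in one place only, so a single exchange can be read on its own: putting 4-formylphenyl in place of 4-ethylphenyl gives a number 20.6 percentage points lower from compound 2 to compound 3 (beyond the scatter). The step is modest but beyond the scatter, which shows that the number responds to what sits on this aromatic carbon, para to a large group, even when the entering and leaving groups both hold 2 heavy atoms. Formyl differs from ethyl by an oxygen, a double bond outside the aromatic rings and a hydrogen-bond acceptor, but a single pair cannot separate these differences, and no measurement here explains the step.

The compounds shown leave open whether an amine, a carboxylic acid or a longer chain such as propyl at this place would give a number nearer that of compound 2 or that of compound 3. They also leave open whether the same exchange would give a step of similar size with cyclohexyl in place of the benzyl group on the shared core.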